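A few compounds are considered here, and "the series" means these few. Any claim that something is new, unique, unknown or untested is made for them only; others in the source may bear on it.

Series notes. In a functional assay on ZR-75-1 cells (Homo sapiens) for cytotoxicity, read by MTT assay, with a stated time of 72 h (on this read-out higher numbers stand for an effect only at larger amounts of compound and lower numbers for an effect already at smaller amounts), compound 1 `CCOC(=O)c1c(C)coc1-c1ccc2c(CC)cccc2c1OC` gives 3.9 ug/mL. Compound 2 `CCCOC(=O)c1c(C)coc1-c1ccc2c(CC)cccc2c1OC` reaches only a limit of the assay, > 10 ug/mL, in this assay. Compound 3 `CCc1cccc2c(OC)c(-c3occ(C)c3COC)ccc12` gives 9.7 ug/mL in this assay.

The change from compound 1 to compound 2 is methyl in place of hydrogen on a saturated chain carbon, two bonds along the chain from an oxygen next to a carbonyl group; it made a step of an at least 2.5-fold higher number from compound 1 to compound 2 (0.40 log units; beyond the scatter), with the number for compound 2 sitting at the limit of > 10 ug/mL in this assay, at which 1 of the 3 values shown sits. From compound 1 to compound 3 the step is a 2.5-fold higher number from compound 1 to compound 3 (0.40 log units; beyond the scatter). Between compound 2 and compound 3 the step is an at least 1.0-fold lower number from compound 2 to compound 3 (0.01 log units; that floor lies within the scatter).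

Compound 4 `CCOc1c(-c2occ(C)c2COC)ccc2c(CC)cccc12` has not been measured in this assay. It differs from compound 3 by methyl in place of hydrogen on a saturated chain carbon bound to an oxygen on an aromatic ring. Among the compounds with values here, this is the same kind of change as the one from compound 1 to compound 2, a methyl entering in place of hydrogen on a saturated chain carbon, but the place differs: in the earlier pair the carbon lies two bonds along the chain from an oxygen next to a carbonyl group, here it is bound to an oxygen on an aromatic ring. The two cores differ as well, by methoxymethyl in place of ethoxycarbonyl on an aromatic carbon.

The step in this assay is expected to be a 1.4-fold higher number from compound 3 to compound 4 (0.16 log units; within the scatter), resting on the earlier methyl step from compound 1 to compound 2 of an at least 2.5-fold higher number from compound 1 to compound 2 (0.40 log units; beyond the scatter) and on compound 3 already standing at 9.7 ug/mL. Compound 4 is estimated at 14 ug/mL in this assay, with a range from 7 ug/mL to 30 ug/mL.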

Compound 4, concentration for half-maximal effect: > 10 ug/mL
Compound 4 gave a limit, no number; the forecaster's own chance of this, stated with the estimate: 65%; the middle value lies beyond the limit too.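

In this assay, methyl in place of hydrogen on a saturated chain carbon bound to an oxygen on an aromatic ring makes an at least 1.0-fold higher number from compound 3 to compound 4 (0.01 log units; that floor lies within the scatter), and this figure is only a floor, since the reading for compound 4 is a limit of the assay and not a number. Placed beside the earlier methyl change, which sits at a different place on the chain and on a different core, the result shows that a larger chain on either core gives no reading better than its parent, but it does not show that the change carries over with the same size: the same change on two cores in this assay, an at least 2.5-fold higher number (0.40 log units; beyond the scatter) from compound 1 to compound 2 and an at least 1.0-fold higher number (0.01 log units; that floor lies within the scatter) from compound 3 to compound 4; the limit leaves it open whether they differ Neither methyl compound gives a true number, so the size of each step remains unknown and no rule for moving this change from one core to another can be drawn from the two pairs: the limit of > 10 ug/mL in this assay, at which 2 of the 4 values shown sit.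

The compounds shown leave open how far past the limit compound 2 and compound 4 lie, and how the methoxy to ethoxy change would read on the core of compound 1. They also leave open whether a longer chain on that oxygen, or an amine or a carboxylic acid in place of the methoxymethyl group, would give a reading that can be measured within the range of the assay.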